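The source may report more compounds than this note shows. Statements on the series, on what has been measured and on what is new or still open speak of the compounds shown alone.

Measured compounds:
Compound 1, `CCCCCCCCCCCCCCCCCCNC(=O)[C@H]1CSC(c2ccc(N(C)C)cc2)N1`, gives 6000 nM in a functional assay on PC-3 cells (Homo sapiens) for antiproliferative activity, read by sulforhodamine B assay; a lower number here means a stronger inhibitor, a higher number a weaker inhibitor.
Compound 2, `CCCCCCCCCCCCCCCCCCNC(=O)[C@H]1CSC(c2cc(F)cc(F)c2)N1`, gives only the limit > 20000 nM in this assay.

Compound 2 thus stands at the limit of this assay, and no number is known for it: the limit of > 20000 nM in this assay, at which 1 of the 2 values shown sits. Among the compounds with values here, the single measured step, an at least 3.3-fold higher number from compound 1 to compound 2 (0.52 log units; beyond the scatter), swapped 4-(dimethylamino)phenyl for 3,5-difluorophenyl on the saturated ring carbon and weakened the compound by an at least modest amount. Compound 3, `CCCCCCCCCCCCCCCCCCNC(=O)[C@H]1CSC(c2c(Cl)cccc2Cl)N1`, carries the change (2,6-dichlorophenyl in place of 3,5-difluorophenyl on a saturated ring carbon). Within the data shown here, no measured step compares one halogenated phenyl ring with another, so the step from compound 1 to compound 2 bears on compound 3 only in showing that the halogenated ring of compound 2 sits at the limit. With nothing pointing to a recovery, compound 3 is expected to stay near that limit, an expected step that the limit leaves unreadable from compound 2 to compound 3. Compound 3 is therefore estimated at 25000 nM, with a range from 8000 nM to 80000 nM.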

Compound 3, half-maximal inhibitory concentration: > 20000 nM
Compound 3: no number, only a limit; the forecaster's own chance of this, stated with the estimate: 70%; the middle value lies beyond the limit too.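

In this assay, the 2,6-dichlorophenyl ring of compound 3 ends at a limit, not a number, just as the 3,5-difluorophenyl ring of compound 2 does, so a second halogenated ring at this saturated ring carbon gives no measurable value: the limit of > 20000 nM in this assay, at which 2 of the 3 values shown sit. Placing 2,6-dichlorophenyl where compound 1 has 4-(dimethylamino)phenyl gives an at least 3.3-fold higher number from compound 1 to compound 3 (0.52 log units; beyond the scatter). Compound 2 and compound 3 both carry only limits, and the step between them cannot be read, which leaves the two halogenated rings unranked.

Compound 1 remains the only one of the three with a real number, and two halogenated rings say little about other groups at this position. Open questions are how a ring bearing a plain amine or a carboxylic acid would read here, and whether a shorter chain would change the picture.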